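A Larger Ring on the Aromatic Nitrogen

The source may report more compounds than this note shows. Statements on the series, on what has been measured and on what is new or still open speak of the compounds shown alone.

In a functional assay on HT-29 cells (Homo sapiens) for inhibition, read by luminescence and CellTiter-Glo, with a stated time of 24 h (a lower number here means that less compound is needed, a higher number that more compound is needed for the effect), compound 1 `CCn1nc(C(=O)N[C@H]2COc3ccccc3N(C)C2=S)nc1Cc1ccccc1` gives 17 nM.
In this assay compound 2 `CN1C(=S)[C@@H](NC(=O)c2nc(Cc3ccccc3)n(CCCCC#N)n2)COc2ccccc21` gives 2680 nM.
In this assay compound 3 `CN1C(=S)[C@@H](NC(=O)c2nc(Cc3ccccc3)n(C3CCC3)n2)COc2ccccc21` gives 181 nM.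

Compound 3 stands second highest of the three numbers, as the steps of an 11-fold higher number from compound 1 to compound 3 (1.03 log units; beyond the scatter) and a 15-fold lower number from compound 2 to compound 3 (1.17 log units; beyond the scatter) show. Compound 4 `CN1C(=S)[C@@H](NC(=O)c2nc(Cc3ccccc3)n(C3CCN(C(=O)OC(C)(C)C)C3)n2)COc2ccccc21` differs from compound 3 by a group of 12 heavy atoms (9 carbon, 1 nitrogen, 2 oxygen; one five-membered non-aromatic ring with 1 hetero atom) in place of a group of 4 heavy atoms (4 carbon; one four-membered non-aromatic ring of carbon only), on an aromatic nitrogen.

Both measured steps concern the group on this same aromatic nitrogen. The step of an 11-fold higher number from compound 1 to compound 3 (1.03 log units; beyond the scatter) and the step of a 160-fold higher number from compound 1 to compound 2 (2.20 log units; beyond the scatter) show that enlarging the group there raised the number strongly, more so for the longer group bearing a nitrile. The entering group is larger again, so a higher number is expected for compound 4, with the step of a 3.9-fold higher number from compound 3 to compound 4 (0.59 log units; beyond the scatter), giving an estimate of 700 nM within 150 nM to 3000 nM.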

Compound 4, half-maximal effective concentration: > 10000 nM
Compound 4: a limit, no number; the forecaster's own chance of this, stated with the estimate: 5%; middle value at least 14-fold (1.15 log units) from the limit.
By their numbers in this assay, from the lowest: compound 1; then compound 3; then compound 2. At a limit, above all of these: compound 4.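

Compound 4 gives a limit of the assay, not a number: the limit of > 10000 nM in this assay, at which 1 of the 4 values shown sits. The steps are therefore only minimum sizes: an at least 55-fold higher number from compound 3 to compound 4 (1.74 log units; beyond the scatter), an at least 3.7-fold higher number from compound 2 to compound 4 (0.57 log units; beyond the scatter) and an at least 580-fold higher number from compound 1 to compound 4 (2.76 log units; beyond the scatter). Across all four compounds, with none going against it, the number rises as the group on this aromatic nitrogen grows, and this largest group sits beyond even 4-cyanobutyl.

The compounds shown leave open whether the five-membered ring or the rest of the entering group matters more. They also leave open how a simple amine or a methyl group would compare at this nitrogen.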